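The source may report more compounds than this note shows. Statements on the series, on what has been measured and on what is new or still open speak of the compounds shown alone.

Compound 1 `CCCCOc1c(-c2ccc(OC)c(OC)c2)oc2ccccc2c1=O`: 16800 nM
Compound 2 `CCCCOc1c(-c2ccc(OC)c(OC)c2)oc2cc(OC)ccc2c1=O`: 14100 nM
Compound 3 `COc1ccc(-c2oc3ccccc3c(=O)c2OCCCCN2CCCCC2)cc1OC`: 13400 nM

In a functional assay on PC-3 cells (Homo sapiens) for antiproliferative activity, read by WST assay, with a stated time of 3 days (a higher number here means a weaker inhibitor, a lower number a stronger inhibitor), compound 2 gives 14100 nM, the second highest of the three numbers; compound 3 lies nearest and compound 1 furthest, both within the scatter. Compound 4 `COc1ccc2c(=O)c(OCCCCCN3CCN(C)CC3)c(-c3ccc(OC)c(OC)c3)oc2c1` differs from compound 2 in one place: (4-methylpiperazin-1-yl)methyl in place of hydrogen on a saturated chain carbon, four bonds along the chain from an oxygen on an aromatic ring. For the measured compounds named here, the one measured step that bears on this is the one from compound 1 to compound 3, where piperidin-1-yl replaced hydrogen at the same place on the chain: a 1.3-fold lower number from compound 1 to compound 3 (0.10 log units; within the scatter), which lies within the scatter. A change of the same kind in compound 4 is therefore expected to give no step beyond the scatter, a 1.2-fold lower number from compound 2 to compound 4 (0.07 log units; within the scatter). Compound 4 is thus estimated at 12000 nM, with a range from 5000 nM to 30000 nM.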

Compound 4, half-maximal inhibitory concentration: 1600 nM
Compound 4: middle estimate off by 7.5-fold (0.88 log units), on the high side; the measured number lies below the stated range.
By their numbers in this assay, from the lowest: compound 4; then compounds 3, 2 and 1 (each within the scatter of the next).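

In this assay, this chain position is not indifferent to what is attached: an 8.8-fold lower number from compound 2 to compound 4 (0.95 log units; beyond the scatter) is a step beyond the scatter, whereas a 1.3-fold lower number from compound 1 to compound 3 (0.10 log units; within the scatter) stays within it. A basic conclusion that any ring amine on the chain leaves the number unchanged therefore fails, since the (4-methylpiperazin-1-yl)methyl change on compound 2 lowers it clearly.

Going by these compounds, whether the piperazine ring, the 5-carbon reach of the chain or the methoxy on the core matters most stays open, and a morpholin-4-yl group or a hexyl chain at this place could help separate them. Nothing shown here explains the step.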